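From 4-methylphenyl to cyclopropyl on the amide-type nitrogen

A few compounds are considered here, and "the series" means these few. Any claim that something is new, unique, unknown or untested is made for them only; others in the source may bear on it.

Measured in a functional assay on MCF7 cells (Homo sapiens) for antiproliferative activity, read by MTT assay, with a stated time of 72 h; a lower number here means a stronger inhibitor, a higher number a weaker inhibitor:
- compound 1 `COc1ncc(-c2ccc3c(c2)N(c2ccc(C)cc2)C(=O)CO3)cc1NS(=O)(=O)c1ccc(F)cc1`: 15400 nM
- compound 2 `O=C1COc2ccc(-c3cnc(Cl)c(NS(=O)(=O)c4ccc(F)cc4)c3)cc2N1c1ccc(F)cc1`: 32600 nM

Compound 1 holds the lower of the two numbers, and the gap to compound 2 lies beyond the scatter. Compound 3 `COc1ncc(-c2ccc3c(c2)N(C2CC2)C(=O)CO3)cc1NS(=O)(=O)c1ccc(F)cc1` has not been measured. It differs from compound 1 by cyclopropyl in place of 4-methylphenyl on an amide-type nitrogen in a ring. Within the data shown here, no measured pair isolates a single change, so the direction is open. In this assay, no step beyond the scatter is expected, an estimated 1.0-fold lower number from compound 1 to compound 3 (0.01 log units; within the scatter). For compound 3 the estimated value is 15000 nM, with an expected range of 3500 nM to 50000 nM.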

Compound 3, half-maximal inhibitory concentration: 35200 nM
Beside the measured number, compound 3's estimate is 2.3-fold (0.37 log units) below it; the range from low to high includes it.
By their numbers in this assay, from the lowest: compound 1; then compounds 2 and 3 (each within the scatter of the next).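

In this assay, among these compounds, the change gives a 2.3-fold higher number from compound 1 to compound 3 (0.36 log units; beyond the scatter), the first single-place step, so the number does respond to the group on this amide-type nitrogen. With the rest of the molecule held fixed, 4-methylphenyl gives the lower number and cyclopropyl the higher one. Nothing measured here accounts for the step.

Only these two groups can be compared at this position, so the effect of ring size or aromatic character cannot be separated from the loss of heavy atoms. A benzyl group or a dimethylaminoethyl chain on this nitrogen remains an open test of how far the position tolerates change.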